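Adding a sulfo group to compound 2

This account rests on a few compounds, and the source may have more. Where it says the series, first, only, none or still open, it means among the compounds named here.

Measured so far in a functional assay on HT-29 cells (Homo sapiens) for antiproliferative activity, with a stated time of 4 h; a higher number here means a weaker inhibitor, a lower number a stronger inhibitor:
compound 1 `O=C1NC(=O)c2c1c1c(O)ccc(O)c1c1[nH]c3ccccc3c21` gives 5600 nM
compound 2 `Cc1ccc2[nH]c3c4c(O)ccc(O)c4c4c(c3c2c1)C(=O)NC4=O` gives 3800 nM

Going by the values given here, compound 2 stands within the usual scatter of compound 1, the only other compound measured. Compound 3 `Cc1ccc2[nH]c3c4c(OS(=O)(=O)O)ccc(O)c4c4c(c3c2c1)C(=O)NC4=O` differs from compound 2 by one change, (sulfo in place of hydrogen on an oxygen on an aromatic ring), which is sulfo in place of hydrogen on an oxygen on an aromatic ring. Among the compounds with values here, the one measured step, a 1.5-fold lower number from compound 1 to compound 2 (0.17 log units; within the scatter), is methyl in place of hydrogen on an aromatic carbon, so it offers only a weak guide. A somewhat higher number is therefore expected in this assay, with wide uncertainty. The estimate means a 2.4-fold higher number from compound 2 to compound 3 (0.37 log units; beyond the scatter) as the expected step. For compound 3 the estimated value is 9000 nM, with an expected range from 2500 nM to 32000 nM in this measurement.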

Compound 3, half-maximal inhibitory concentration: 50000 nM
For compound 3 the middle estimate is 5.6-fold (0.74 log units) below the measured one; the measured number lies above the stated range.
By their numbers in this assay, from the lowest: compounds 2 and 1 (each within the scatter of the next); then compound 3.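

In this assay, going by these compounds alone, replacing hydroxy with sulfooxy gives a 13-fold higher number from compound 2 to compound 3 (1.12 log units; beyond the scatter), while the only earlier step stayed within the scatter. This oxygen on an aromatic ring is therefore the first place shown where a single change clearly weakens the compound. Nothing measured here explains the size of this step.

The compounds shown leave open whether an acetyl group or a longer alkyl chain on the same oxygen would raise the number as much. From the compounds shown here alone, it also remains open whether sulfo on the other hydroxy would act alike.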